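Adding a bromine to the phenyl ring: what to expect

The compounds below may be only part of what the source reports. "The series", "measured", "known", "first", "only" and "open" are said of these compounds alone.

Measured so far:
compound 1, `O=C1NC(=S)S/C1=C\C=C\c1ccccc1OCc1ccncc1`, in a functional assay on DLD-1 cells (Homo sapiens), read by microscopy and crystal violet staining, with a stated time of 20 h, tested at 10 ug/mL (on this read-out higher numbers stand for more inhibition at the one concentration tested (going by the name of the read-out) and lower numbers for less inhibition), compound 1 gives 62%.
compound 2, `O=C1NC(=S)S/C1=C\C=C\c1ccccc1OCc1ccccc1Br`, in this assay compound 2 gives 78%.

Of the two measured compounds, compound 2 stands highest in this assay; the nearest is compound 1, and the step of a number 16 percentage points higher from compound 1 to compound 2 (beyond the scatter) exchanged the group on the saturated chain carbon bound to an oxygen on an aromatic ring. Compound 3, `O=C1NC(=S)S/C1=C\C=C\c1cc(Br)ccc1OCc1ccccc1Br`, differs from compound 2 in a different place: bromo in place of hydrogen on an aromatic carbon, on an aromatic carbon of a six-membered aromatic ring of carbon only, meta to a large group and para to a group of 9 heavy atoms. Going by the values given here, no measured step touches that ring, so the single step seen gives no direct guide. With the shared core and the 2-bromophenyl group of compound 2 kept, compound 3 is expected to change by about a number 1 percentage points higher from compound 2 to compound 3 (within the scatter), a step most likely within the scatter. Compound 3 is therefore estimated at 79%, with a range from 62% to 93%.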

Compound 3, a percentage reported as inhibition, at one concentration (the size of the read-out at that concentration, not a potency): 71%
Compound 3: middle estimate off by 8 percentage points, on the high side; the measured number falls inside the stated range.
By their numbers in this assay, from the lowest: compounds 1, 3 and 2 (each within the scatter of the next, the first and the last beyond it).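

Bromo in place of hydrogen on an aromatic carbon, meta to a large group and para to a group of 9 heavy atoms, is the only change shown on this ring, and in this assay it gives a number 7 percentage points lower from compound 2 to compound 3 (within the scatter). This position therefore carries a bromine with no difference from compound 2 that can be told apart from ordinary assay scatter, though a percentage at one concentration is not a measure of potency. Nothing measured here bears on why the number came out this way.

From the compounds shown here alone, whether an amine or a carboxylic acid on this same carbon would move the number beyond the scatter remains open. So does whether this bromine would behave the same way with the pyridin-4-yl group of compound 1 in place of the 2-bromophenyl group.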